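This account rests on a few compounds, and the source may have more. Where it says the series, first, only, none or still open, it means among the compounds named here.

For the measured compounds named here, compound 2, with the structure `CCCN(CCC)c1nc(C)nc2c(-c3ccc(Cl)cc3Cl)c(C)nn12`, stands lowest of the two numbers measured so far in an assay on isolated protein for displacement of a labelled ligand from corticotropin-releasing factor receptor 1 (Homo sapiens); on this read-out lower numbers stand for stronger inhibition and higher numbers for weaker inhibition; its nearest neighbour is compound 1, `CCCN(CC1CC1)c1nc(C)nc2c(-c3ccc(Cl)cc3Cl)c(C)nn12`, and the two lie within the scatter of each other. In this assay compound 1 gives 0.7 nM, and compound 2 gives 0.6 nM. Going by the values given here, the one measured step, a 1.2-fold lower number from compound 1 to compound 2 (0.07 log units; within the scatter), is small and concerns only the chain on the ring nitrogen.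

Compound 3, `CCCCC(CC)Nc1nc(C)nc2c(-c3ccc(Cl)cc3Cl)c(C)nn12`, differs from compound 2 by the change ((1-ethylpentyl)amino in place of dipropylamino on an aromatic carbon), that is, a secondary amine bearing a branched chain in place of a tertiary amine bearing two propyl chains. Among the compounds with values here, no measured step touches the amine hydrogen itself; the step from compound 1 to compound 2 shows only that a change at a chain on this nitrogen was within the scatter. On that thin basis the expectation for compound 3 in this assay is a step of about a 2.5-fold higher number from compound 2 to compound 3 (0.40 log units; beyond the scatter), most likely within the scatter or a little weaker. Compound 3 is therefore estimated at 1.5 nM, with a range from 0.4 nM to 6 nM.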

Compound 3, inhibition constant: 1.6 nM
Estimate against measurement, compound 3: 1.1-fold (0.03 log units) below; the measured number falls inside the stated range.
By their numbers in this assay, from the lowest: compounds 2 and 1 (each within the scatter of the next); then compound 3.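

Replacing dipropylamino with (1-ethylpentyl)amino on the aromatic carbon between two ring nitrogen atoms gives, in this assay, a 2.7-fold higher number from compound 2 to compound 3 (0.43 log units; beyond the scatter), which is beyond the scatter and modest, whereas the earlier change between the two tertiary amines stayed within it. The change from (cyclopropylmethyl)(propyl)amino gives a 2.3-fold higher number from compound 1 to compound 3 (0.36 log units; beyond the scatter), also modest, so compound 3 stands apart from both tertiary amines, yet the secondary amine bearing a branched chain, with its hydrogen-bond donor, still leaves compound 3 at 1.6 nM. Nothing measured here accounts for this shift.

The step alters the amine hydrogen and the shape of the chain together, so the compounds shown do not separate what each contributes. Also open, going by these compounds, is how this assay would read for a secondary amine with a straight hexyl chain, for a tertiary amine carrying the 1-ethylpentyl chain plus a methyl group, or for a ring amine such as morpholine on the same carbon.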